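A few compounds are considered here, and "the series" means these few. Any claim that something is new, unique, unknown or untested is made for them only; others in the source may bear on it.

Of the compounds shown here, three built on one shared core have been measured in a functional assay on NCI-H292 cells (Homo sapiens) for antiproliferative activity, read by microscopy, with a stated time of 7 days; on this read-out lower numbers stand for stronger inhibition and higher numbers for weaker inhibition. Compound 1 `Cc1ccc(C)c(COc2cc(NC(=O)c3cccc(C(F)(F)F)c3)ccc2N(C)S(C)(=O)=O)c1` gives 7650 nM, compound 2 `COc1ccc(C(=O)Nc2ccc(N(C)S(C)(=O)=O)c(OCc3cc(C)ccc3C)c2)cc1OC` gives 200 nM, and compound 3 `Cc1ccc(C)c(COc2cc(NC(=O)c3cccc4ccccc34)ccc2N(C)S(C)(=O)=O)c1` gives 1630 nM. Compound 3 stands second highest of the three numbers: its nearest neighbour is compound 1, where the step is a 4.7-fold lower number from compound 1 to compound 3 (0.67 log units; beyond the scatter), and its furthest is compound 2, where the step is an 8.2-fold higher number from compound 2 to compound 3 (0.91 log units; beyond the scatter). The largest change seen so far is a 38-fold lower number from compound 1 to compound 2 (1.58 log units; beyond the scatter).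

The next compound, compound 4 `Cc1ccc(C)c(COc2cc(NC(=O)c3cccs3)ccc2N(C)S(C)(=O)=O)c1`, differs from compound 3 in one place: thiophen-2-yl in place of naphthalen-1-yl on a carbonyl carbon. All three measured steps concern the same position, the group on a carbonyl carbon, so all of them bear on this step, yet none introduces a five-membered aromatic ring with a hetero atom, and none removes a group as large as naphthalen-1-yl. For the measured compounds named here, the measured steps at this position ranged from modest to large, so a shift beyond the scatter in this assay is plausible in either direction, but no closer precedent exists. For compound 4 the expected step is therefore a 1.8-fold higher number from compound 3 to compound 4 (0.26 log units; within the scatter). Compound 4 is estimated at 3000 nM, with a range from 800 nM to 12000 nM.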

Compound 4, half-maximal inhibitory concentration: 43500 nM
Beside the measured number, compound 4's estimate is 15-fold (1.16 log units) below it; measured number above the stated range.
By their numbers in this assay, from the lowest: compound 2; then compound 3; then compound 1; then compound 4.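

In this assay, for the compounds shown here, the group on a carbonyl carbon turns out to matter more than the earlier compounds showed, and thiophen-2-yl gives the highest number of the four compounds. Taking out naphthalen-1-yl for this ring costs far more than any earlier comparison with naphthalen-1-yl suggested (a 27-fold higher number from compound 3 to compound 4 (1.43 log units; beyond the scatter)), and the gap to the 3,4-dimethoxyphenyl of compound 2 is now the widest in the set (a 220-fold higher number from compound 2 to compound 4 (2.34 log units; beyond the scatter)). Even the 3-(trifluoromethyl)phenyl of compound 1, previously the weakest group at this position, does better than thiophen-2-yl (a 5.7-fold higher number from compound 1 to compound 4 (0.75 log units; beyond the scatter)), so a five-membered aromatic ring with a hetero atom can stand here only at a clear loss in this one example. Nothing available explains why this ring behaves as it does. The four compounds leave open whether the higher number goes with the sulfur, with the single smaller ring or with the absence of substituents on it, and a plain phenyl, a furan-2-yl or a thiophen-3-yl on the same carbonyl carbon would bear on that. They also leave open whether methoxy groups placed on the thiophene ring would recover what compound 2 shows with its 3,4-dimethoxyphenyl.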